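Cytotoxicity notes: trifluoromethoxyphenyl in place of indolyl

This account rests on a few compounds, and the source may have more. Where it says the series, first, only, none or still open, it means among the compounds named here.

Compound 1 `CC(C)N(Cc1cccc(OCCCCCC(=O)O)c1)C(=O)c1ccc(-c2ccsc2)cc1`: in an ADME assay on Raji cells (Homo sapiens) for cytotoxicity, read by CellTiter-Glo and resazurin assay, with a stated time of 72 h (on this read-out higher numbers stand for an effect only at larger amounts of compound and lower numbers for an effect already at smaller amounts), compound 1 gives > 26000 nM, which is a limit of the assay and not a number.
Compound 2 `CC(C)N(Cc1cccc(OCCCCCC(=O)O)c1)C(=O)c1ccc(-c2cccc(OCc3ccccc3)c2)cc1`: compound 2 gives > 26000 nM, again a limit.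
Compound 3 `CC(C)N(Cc1cccc(OCCCCCC(=O)O)c1)C(=O)c1ccc(-c2ccc3[nH]ccc3c2)cc1`: compound 3 gives > 26000 nM, also a limit.

Within the data shown here, all three measured compounds in this assay therefore sit at the limit of > 26000 nM in this assay, at which 3 of the 3 values shown sit, and compound 3 stands nowhere more precisely than that: no number, only the limit, and no measured compound sets itself apart from it. Compound 4 `CC(C)N(Cc1cccc(OCCCCCC(=O)O)c1)C(=O)c1ccc(-c2cccc(OC(F)(F)F)c2)cc1` differs from compound 3 in one place: 3-(trifluoromethoxy)phenyl in place of 1H-indol-5-yl on an aromatic carbon. Among the measured compounds shown here, the one measured step that bears on this position, a step that the two limits leave unreadable from compound 1 to compound 3, is unreadable, since both ends are limits; it gives no direction and no size. Nothing in the series shows a readable change at this position, so no step beyond the scatter is expected for this assay, and compound 4 is estimated to remain at the limit as well. The expected step that the limit leaves unreadable from compound 3 to compound 4 is none beyond the scatter. For compound 4 the estimate is 30000 nM, with a range from 15000 nM to 80000 nM, most likely reported only as a limit.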

Compound 4, half-maximal effective concentration: > 26000 nM
Compound 4: no number, only a limit (the forecaster's own chance of this, stated with the estimate: 85%); the middle value does not contradict the limit.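

In this assay compound 4 gives > 26000 nM, a limit of the assay and not a number, so the steps to it from compound 1, compound 2 and compound 3 cannot be read. The compounds shown leave open at what concentration any of them would show cytotoxicity.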